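Triazole amide series: dichlorophenyl replacement at the triazole nitrogen

A few compounds are considered here, and "the series" means these few. Any claim that something is new, unique, unknown or untested is made for them only; others in the source may bear on it.

Measured compounds in a functional assay on NCI-H460 cells (Homo sapiens) for cytotoxicity, read by MTT assay, with a stated time of 72 h; on this read-out lower numbers stand for stronger inhibition and higher numbers for weaker inhibition:
- compound 1 `COc1cc2c(Oc3ccc(NC(=O)c4cn(-c5ccccc5Cl)nn4)cc3F)ccnc2cc1OCCCN1CCC(C)CC1`: 230 nM
- compound 2 `COc1cc2c(Oc3ccc(NC(=O)c4cn(-c5ccccc5C)nn4)cc3F)ccnc2cc1OCCCN1CCC(C)CC1`: 2730 nM

Compound 2 stands with the highest number of the two measured. Going by the values given here, its nearest neighbour is compound 1, and the only measured step is a 12-fold higher number from compound 1 to compound 2 (1.07 log units; beyond the scatter).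

Compound 3 `COc1cc2c(Oc3ccc(NC(=O)c4cn(-c5c(Cl)cccc5Cl)nn4)cc3F)ccnc2cc1OCCCN1CCC(C)CC1` is not yet measured. It differs from compound 2 by 2,6-dichlorophenyl in place of 2-methylphenyl on an aromatic nitrogen. Among the compounds with values here, this change both reverses the one measured step and adds a second chlorine. Within the data shown here, the single step that bears on it, a 12-fold higher number from compound 1 to compound 2 (1.07 log units; beyond the scatter), was large, so a large step in the opposite direction is expected in this assay, bringing compound 3 back toward the range of compound 1. The effect of the second chlorine is not covered by any measured pair, which widens the range. The expected step is a 7.8-fold lower number from compound 2 to compound 3 (0.89 log units; beyond the scatter). Compound 3 is estimated at 350 nM with a range of 110 nM to 1200 nM.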

Compound 3, half-maximal inhibitory concentration: 270 nM
Compound 3: middle estimate off by 1.3-fold (0.11 log units), on the high side, within the range that was stated.
By their numbers in this assay, from the lowest: compounds 1 and 3 (each within the scatter of the next); then compound 2.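

In this assay, 2,6-dichlorophenyl in place of 2-methylphenyl on the aromatic nitrogen gives a 10-fold lower number from compound 2 to compound 3 (1.00 log units; beyond the scatter), so a second ring carrying chlorine at this position also stands clear of the methyl compound. Going by these compounds alone, the effect of the second chlorine, which no earlier pair covered, can now be read: the step is a 1.2-fold higher number from compound 1 to compound 3 (0.07 log units; within the scatter), so compound 1 and compound 3 cannot be told apart in this assay. No measurement on hand explains either step.

The compounds shown leave open how an unsubstituted phenyl would compare at this position, and so whether chlorine lowers the number or methyl raises it. A 2,6-dimethylphenyl or a 2-methoxyphenyl would also test whether the gap between the chlorine compounds and compound 2 holds beyond these three.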